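The source may report more compounds than this note shows. Statements on the series, on what has been measured and on what is new or still open speak of the compounds shown alone.

Series notes. Compound 1 `O=S(=O)(Nc1cccc2c1CCCC2c1c[nH]cn1)C1CC1` has been measured in an assay on isolated protein for binding affinity to Alpha-1A adrenergic receptor (Rattus norvegicus), read by radioligand binding (on this read-out lower numbers stand for stronger inhibition and higher numbers for weaker inhibition), and gives 537 nM. Among the three numbers recorded so far it stands highest. Compound 2 `CS(=O)(=O)Nc1cccc2c1OCCC2c1c[nH]cn1` gives 479 nM in this assay; this value and that of compound 1 lie within the usual scatter of each other, so nothing separates the two. Compound 3 `CCS(=O)(=O)Nc1cc(Cl)cc2c1CCCC2c1c[nH]cn1` gives 45.7 nM in this assay, a number well below that of compound 1 and beyond the scatter. For the measured compounds named here, no two measured compounds differ in a single place, so no step between measured compounds can be read off.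

Compound 4 `O=C(Nc1cccc2c1CCCC2c1c[nH]cn1)C(F)(F)F` has not yet been measured in this assay. It differs from compound 1 in one place: (trifluoromethyl)carbonyl in place of cyclopropylsulfonyl on a nitrogen on an aromatic ring. Going by the values given here, no measured pair shows this change, so the expectation for compound 4 rests on compound 1 alone. The step from compound 1 to compound 4 is expected to be small, a 1.4-fold higher number from compound 1 to compound 4 (0.15 log units; within the scatter), close to the scatter, with the number somewhat more likely to rise than to fall. Compound 4 is accordingly estimated at 750 nM in this assay, within a range of 250 nM to 2200 nM.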

Compound 4, inhibition constant: 166 nM
Estimate against measurement, compound 4: 4.5-fold (0.65 log units) above, and the stated range ends above it.
By their numbers in this assay, from the lowest: compound 3; then compound 4; then compounds 2 and 1 (each within the scatter of the next).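

For the compounds shown here, on a nitrogen on an aromatic ring of the core of compound 1, the sulfonyl link is not needed for binding in this assay: (trifluoromethyl)carbonyl in place of cyclopropylsulfonyl gives a 3.2-fold lower number from compound 1 to compound 4 (0.51 log units; beyond the scatter), the first step that can be read. The entering group has no ring, so at this position the three-membered ring of cyclopropylsulfonyl is not required for a number of this size either. No measurement at hand bears on why the number falls.

This single pair does not separate the loss of the sulfonyl from the gain of the trifluoromethyl, a question that a plain acetyl on the same nitrogen would address. On these data alone, whether the step carries over to the cores of compound 2 and compound 3 also stays open.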